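The source may hold more compounds than are shown below. What is called first, only, known or untested is meant among the compounds shown, and "the series" means these compounds.

In an ADME assay on NIH3T3 cells (Mus musculus) for cytotoxicity, read by MTT assay, with a stated time of 24 h (a higher number here means a weaker inhibitor, a lower number a stronger inhibitor), compound 1 `O=C(CSc1ncccn1)N/N=c1/scc(-c2ccc(Br)cc2)n1-c1ccccc1` gives 273 ug/mL, and compound 2 `COc1ccc(-c2cs/c(=N/NC(=O)CSc3ncccn3)n2-c2ccccc2)cc1` gives 450 ug/mL, a pair of numbers that lie within the scatter of each other, a 1.6-fold higher number from compound 1 to compound 2 (0.22 log units; within the scatter). Compound 3 `N#Cc1ccc(-c2cs/c(=N/NC(=O)CSc3ncccn3)n2-c2ccccc2)cc1` stands apart: its result is only a limit of this assay, < 3.9 ug/mL (the limit of < 3.9 ug/mL in this assay, at which 1 of the 3 values shown sits). The steps leading to it were large, an at least 70-fold lower number from compound 1 to compound 3 (1.84 log units; beyond the scatter) and an at least 110-fold lower number from compound 2 to compound 3 (2.06 log units; beyond the scatter). Compound 4 `Cc1ccc(-c2cs/c(=N/NC(=O)CSc3ncccn3)n2-c2ccccc2)cc1` removes that cyano group: methyl in place of cyano on an aromatic carbon. The two large measured steps both ran toward the cyano compound, so the reverse change is expected to run back the other way, with a large rise in this assay, an at least 76-fold higher number from compound 3 to compound 4 (1.88 log units; beyond the scatter), toward the numbers of compound 1 and compound 2. Compound 4 is therefore estimated at 300 ug/mL, between 80 ug/mL and 700 ug/mL.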

Compound 4, half-maximal inhibitory concentration: > 500 ug/mL
Compound 4 ended at the assay's limit (the forecaster's own chance of this, stated with the estimate: 10%); at least 1.6-fold (0.22 log units) between middle value and limit.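

In this assay the change from the 4-cyanophenyl to the 4-methylphenyl group is a large one (an at least 120-fold higher number from compound 3 to compound 4 (2.10 log units; beyond the scatter)), so a third group at this place, para to a large group, parts from cyano. Methyl cannot be ordered against methoxy (an at least 1.1-fold higher number from compound 2 to compound 4 (0.04 log units; that floor lies within the scatter)) or bromo (an at least 1.8-fold higher number from compound 1 to compound 4 (0.26 log units; that floor lies within the scatter)), since both floors lie within the scatter. The result for compound 4 is a limit of the assay: the limit of > 500 ug/mL in this assay, at which 1 of the 4 values shown sits.

On these data alone, with compound 3 also only a limit, the full size of the step remains open. As far as these compounds go, whether an amine or a carboxylic acid here would fall with cyano or with the other three groups also remains open.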